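The compounds below may be only part of what the source reports. "The series", "measured", "known", "first", "only" and "open" are said of these compounds alone.

Working notes on the series.

Compound 1 `CC1CCC(=O)N1CC#CCn1ccnc1` gives 20.9 mg/kg in a functional assay on the whole organism for antagonist activity, with Mus musculus as the target; a lower number here means that less compound is needed, a higher number that more compound is needed for the effect. Compound 2 `CC1CCC(=O)N1CC#CCN(C)C` is read only as a limit of this assay, at > 100 mg/kg. The step of an at least 4.7-fold higher number from compound 1 to compound 2 (0.67 log units; beyond the scatter) rests on (dimethylamino in place of 1H-imidazol-1-yl on a saturated chain carbon bound to a triple-bonded carbon); the limit of > 100 mg/kg in this assay, at which 2 of the 3 values shown sit, means its true size is open upward.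

Compound 3 `COC(=O)N(C)CC#CCn1ccnc1` is likewise read only as a limit of this assay, at > 100 mg/kg. The difference between the core of compound 3 and the core of compound 1 is not broken down here.

Compound 4 `COC(=O)N(C)CC#CCN(C)C` is yet to be measured. Its relation to compound 3 is dimethylamino in place of 1H-imidazol-1-yl on a saturated chain carbon bound to a triple-bonded carbon, the same kind of change as from compound 1 to compound 2. Given that compound 3 already sits at a limit, and that the earlier step was at least modest, compound 4 is expected to show a step that the limit leaves unreadable from compound 3 to compound 4 and a value near 300 mg/kg, most likely again reported only as a limit.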

Compound 4, dose for half-maximal effect: > 30 mg/kg
Compound 4 ended at the assay's limit (the forecaster's own chance of this, stated with the estimate: 90%); the middle value does not contradict the limit.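

Compound 3 is only a limit, at > 100 mg/kg. For the compounds shown here, compound 4 is also only a limit, at > 30 mg/kg, and no step between compound 3 and compound 4 can be read. The compounds shown leave open whether dimethylamino in place of 1H-imidazol-1-yl changes the dose on the core of compound 3.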